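The source may report more compounds than this note shows. Statements on the series, on what has been measured and on what is new or still open speak of the compounds shown alone.

Values in a functional assay on HCT-116 cells (Homo sapiens) for antiproliferative activity, with a stated time of 72 h; on this read-out higher numbers stand for weaker inhibition and lower numbers for stronger inhibition:
- compound 1 `COc1cc(OCC(=O)NO)ccc1CNCCn1cnc2ccccc21`: > 10000 nM
- compound 2 `O=C(COc1ccc(CN2CC=C(c3c[nH]c4cccc(F)c34)CC2)c(F)c1)NO`: 1220 nM
- compound 3 `Cc1ccc2[nH]cc(C3=CCN(Cc4ccc(OCC(=O)NO)cc4F)CC3)c2c1`: 1450 nM

Compound 1 gives a limit of the assay and not a number.

Compound 3 has a single numerical neighbour and sits within the scatter of it. For the measured compounds named here, the one measured step is a 1.2-fold higher number from compound 2 to compound 3 (0.08 log units; within the scatter), an exchange of 4-fluoro-1H-indol-3-yl for 5-methyl-1H-indol-3-yl on the double-bonded ring carbon.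

Next in the series is compound 4 `Cc1[nH]c2ccccc2c1C1=CCN(Cc2ccc(OCC(=O)NO)cc2F)CC1`, which has the same atoms as compound 3, joined differently: 2-methyl-1H-indol-3-yl in place of 5-methyl-1H-indol-3-yl on a double-bonded ring carbon. Going by the values given here, the same ring carbon is involved, so the measured exchange is the only guide, though 2-methyl-1H-indol-3-yl itself has no measured precedent here. Since a 1.2-fold higher number from compound 2 to compound 3 (0.08 log units; within the scatter) stayed within the scatter, no step beyond the scatter is expected in this assay, in either direction, and the range is kept wide for want of further steps. The expected step is a 1.0-fold higher number from compound 3 to compound 4 (0.01 log units; within the scatter). The estimated value for compound 4 is 1500 nM, with an expected range of 600 nM to 4000 nM.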

Compound 4, half-maximal inhibitory concentration: 1220 nM
Beside the measured number, compound 4's estimate is 1.2-fold (0.09 log units) above it; low and high end bracket the measured number.
By their numbers in this assay, from the lowest: compounds 2, 4 and 3 (each within the scatter of the next). At a limit, above all of these: compound 1.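

In this assay, 2-methyl-1H-indol-3-yl in place of 5-methyl-1H-indol-3-yl gives a 1.2-fold lower number from compound 3 to compound 4 (0.08 log units; within the scatter), and 2-methyl-1H-indol-3-yl in place of 4-fluoro-1H-indol-3-yl gives no change at the digits printed from compound 2 to compound 4 (within the scatter). The 2-methyl-1H-indol-3-yl group, new at this double-bonded ring carbon, therefore falls in the same band as the other two indolyl groups, so the three groups shown at this position are not separated by this read-out. No measured property among the data at hand bears on this flat result.

Still open, from the compounds shown here alone, is whether an amine, a carboxylic acid or a longer chain on the indolyl group would give a step beyond the scatter. The unsubstituted 1H-indol-3-yl group would also give a reference for all three exchanges.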